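Ring-nitrogen methyl-to-ethyl in a polar oxime series

This account rests on a few compounds, and the source may have more. Where it says the series, first, only, none or still open, it means among the compounds named here.

Measured compounds in a physicochemical assay for lipophilicity; a lower number here means a more polar compound, a higher number a more lipophilic compound:
compound 1, `CC[n+]1ccn(COCC(C)(C)[N+](=O)[O-])c1/C=N/O`: -1.77
compound 2, `CC[n+]1ccn(COCCS(C)(=O)=O)c1/C=N/O`: < -3
compound 3, `CCS(=O)(=O)CCOCn1cc[n+](C)c1/C=N/O`: < -2.7

Compound 3 sits at the floor of the series: its value in this assay is a limit of the assay, not a number, and it stands at the limit of < -2.7 in this assay, at which 1 of the 3 values shown sits. Going by the values given here, compound 2 likewise returns only a limit, (the limit of < -3 in this assay, at which 1 of the 3 values shown sits), while compound 1 is the one member with a measured number.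

Compound 4, `CC[n+]1ccn(COCCS(=O)(=O)CC)c1/C=N/O`, differs from compound 3 in one place: methyl in place of hydrogen on a saturated chain carbon bound to an aromatic nitrogen. Cut one bond further out, the change reads methyl to ethyl on the ring nitrogen.

Among the compounds with values here, the only measured step, a number at least 1.23 log units lower from compound 1 to compound 2 (beyond the scatter), concerns the chain end bound to the ether oxygen, not the ring nitrogen, so it does not bear directly on this change. Within the data shown here, compound 2 and compound 4 share the ethyl on the ring nitrogen and differ in the sulfonyl substituent; compound 2 gives only a limit, and no step between them is measured.

The expected step of a number at least 0.10 log units higher from compound 3 to compound 4 (that floor lies within the scatter) is small, within the scatter or just beyond it, towards the lipophilic side. Compound 4 is therefore estimated at -2.6, with a range from -3.2 to -2, and a real chance that this assay again reports only a limit.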

Compound 4, distribution coefficient: -2.67
For compound 4 the middle estimate is 0.07 log units above the measured one; the measured number falls inside the stated range.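

In this assay compound 4 returns -2.67, the only number among the sulfonyl compounds shown, while methyl in place of hydrogen on a saturated chain carbon bound to an aromatic nitrogen is held only to a floor, a number at least 0.03 log units higher from compound 3 to compound 4 (that floor lies within the scatter). Compound 3 is a limit of the assay, not a number: the limit of < -2.7 in this assay, at which 1 of the 4 values shown sits. Going by these compounds alone, the sulfonyl end gives more to read: methyl in place of hydrogen on a saturated chain carbon bound to a sulfonyl sulfur gives another floor, this one clear of the scatter, a number at least 0.33 log units higher from compound 2 to compound 4 (beyond the scatter), and (ethylsulfonyl)methyl in place of 1-methyl-1-nitroethyl gives the one new step with a number at both ends, a number 0.90 log units lower from compound 1 to compound 4 (beyond the scatter).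

The true size of the change from methyl to ethyl stays unfixed, as one end of that pair is a limit and the step could be anything from negligible to clearly larger. Also open, from the compounds shown here alone, is whether a longer chain such as propyl at that same place, or an amine or a carboxylic acid in place of the sulfonyl group at the chain end, would give numbers rather than limits.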